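The compounds below may be only part of what the source reports. "The series", "measured", "known", "first", "only" and "open" are said of these compounds alone.

Compound 1 `CCCOc1ccc(C(=O)Nc2cccc(Cl)n2)cc1` in an in vitro assay on HEK-tsA201 cells for antagonist activity at Neuronal acetylcholine receptor; alpha3/beta4 (Homo sapiens), read by fluorescence and calcium flux (a lower number here means a stronger inhibitor, a higher number a weaker inhibitor), gives > 100000 nM, which is a limit of the assay.
Compound 2 `CCCOc1ccc(C(=O)Nc2cccc(Nc3ccc(F)cc3)n2)cc1` in this assay gives > 100000 nM, likewise a limit.

Compound 2 therefore stands at the limit itself, as shown by the limit of > 100000 nM in this assay, at which 2 of the 2 values shown sit. For the measured compounds named here, the only measured step, a step that the two limits leave unreadable from compound 1 to compound 2, is unreadable and gives compound 3 no guide. Compound 3 `CCCOc1ccc(C(=O)Nc2cccc(NCc3ccccc3)n2)cc1` differs from compound 2 by benzyl in place of 4-fluorophenyl on a nitrogen on an aromatic ring. With no readable step, no change beyond the scatter in this assay is expected in either direction. For compound 3 the estimate in this assay is 100000 nM, between 30000 nM and 300000 nM. That corresponds to an expected step of a number no higher from compound 2 to compound 3 (the limit leaves the size open), and compound 3 is expected most likely to return a limit again.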

Compound 3, half-maximal inhibitory concentration: > 100000 nM
Compound 3: no number, only a limit; the forecaster's own chance of this, stated with the estimate: 70%; the middle value sits exactly at the limit.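

In this assay compound 3 gives > 100000 nM, a limit, and the steps from compound 1 and from compound 2 to compound 3 cannot be read. The compounds shown leave open how these three compare, and which change to the shared core would yield a measurable number.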